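Alkyl cyclic-phosphate nucleoside series: toward the isopropyl analogue

The compounds below may be only part of what the source reports. "The series", "measured", "known", "first", "only" and "open" are said of these compounds alone.

Three members of the series have been run in a functional assay on L1210 cells (Mus musculus) for cytotoxicity; a higher number here means a weaker inhibitor, a lower number a stronger inhibitor. Compound 1 `CCCCCCc1cn([C@@H]2O[C@@H]3COP(=O)(O)O[C@H]3[C@H]2O)c(=O)nc1N` carries a hexyl chain on the shared core. In this assay compound 1 reports only the limit > 200 ug/mL and not a number. Compound 2 `CCc1cn([C@@H]2O[C@@H]3COP(=O)(O)O[C@H]3[C@H]2O)c(=O)nc1N` carries an ethyl chain at the same place. For compound 2 this assay likewise stops at the limit > 200 ug/mL. Compound 3 `CCCCc1cn([C@@H]2O[C@@H]3COP(=O)(O)O[C@H]3[C@H]2O)c(=O)nc1N` carries a butyl chain. For compound 3 this assay again gives only the limit > 200 ug/mL. Where compound 3 stands is thus known solely as a limit, and the two other values are limits as well. The measured steps are a step that the two limits leave unreadable from compound 1 to compound 2, a step that the two limits leave unreadable from compound 1 to compound 3 and a step that the two limits leave unreadable from compound 2 to compound 3; none of them can be read because of the limit of > 200 ug/mL in this assay, at which 3 of the 3 values shown sit.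

Compound 4 `CC(C)c1cn([C@@H]2O[C@@H]3COP(=O)(O)O[C@H]3[C@H]2O)c(=O)nc1N` has not yet been measured. It differs from compound 3 by isopropyl in place of butyl on an aromatic carbon. All three measured steps concern the same chain, but none carries a readable size, so the step of a number no higher from compound 3 to compound 4 (the limit leaves the size open) is expected to be too small to stand out from the scatter. Compound 4 is therefore expected to give 200 ug/mL in this assay, within 100 ug/mL to 400 ug/mL, most likely reported once more only as a limit.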

Compound 4, concentration for 50% inhibition: > 200 ug/mL
Compound 4: a limit, no number; the forecaster's own chance of this, stated with the estimate: 85%; the middle value sits exactly at the limit.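

In this assay, no new step can be read between compound 4 and compound 1, compound 2 or compound 3 because all four compounds end at the same limit: the limit of > 200 ug/mL in this assay, at which 4 of the 4 values shown sit.

The compounds shown leave open whether any chain on the shared core gives a numerical value in this read-out, and so how chain length or branching bears on cytotoxicity.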